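The source may report more compounds than this note shows. Statements on the series, on what has been measured and on what is new or still open speak of the compounds shown alone.

In an assay on HEK293 cells for displacement of a labelled ligand from 5-hydroxytryptamine receptor 7 (Homo sapiens) (a higher number here means a weaker inhibitor, a lower number a stronger inhibitor), the measured compounds are:

compound 1, `CC1(c2ccc(F)cc2)NC(=O)N(CC(O)CN2CCN(c3ccccc3)CC2)C1=O`: 223 nM
compound 2, `CC1(c2ccc(F)cc2)NC(=O)N(CC(O)CN2CCN(c3ccccc3F)CC2)C1=O`: 234 nM
compound 3, `CC1(c2ccc(F)cc2)NC(=O)N(CC(O)CN2CCN(c3ccccc3C#N)CC2)C1=O`: 14 nM

Of these three numbers, compound 1 sits second highest in this assay; compound 2 is nearest, and the step of a 1.0-fold higher number from compound 1 to compound 2 (0.02 log units; within the scatter) lies within the scatter. Compound 3 stands furthest away, with the step of a 16-fold lower number from compound 1 to compound 3 (1.20 log units; beyond the scatter) well beyond the scatter, and a 17-fold lower number from compound 2 to compound 3 (1.22 log units; beyond the scatter) tells the same story from compound 2.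

Compound 4, `CC1(c2ccc(F)cc2)NC(=O)N(CC(O)CN2CCN(c3ccc(F)cc3)CC2)C1=O`, differs from compound 1 in one spot: fluoro in place of hydrogen on an aromatic carbon. Among the measured compounds shown here, the step from compound 1 to compound 2 is the only measured change that adds a fluoro to this phenyl ring, and it changed nothing beyond the scatter, though there the fluoro sat elsewhere on the ring. The large gain seen with compound 3 came from a cyano, not a fluoro, so it does not carry over. Compound 4 is therefore expected to stay close to compound 1, with the step of a 1.1-fold lower number from compound 1 to compound 4 (0.05 log units; within the scatter) at most modest. The estimate for compound 4 in this assay is 200 nM, within a range from 80 nM to 500 nM.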

Compound 4, inhibition constant: 837 nM
For compound 4 the middle estimate is 4.2-fold (0.62 log units) below the measured one, and the stated range ends below it.
By their numbers in this assay, from the lowest: compound 3; then compounds 1 and 2 (each within the scatter of the next); then compound 4.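

Fluoro on this phenyl ring does not always leave the number unchanged: in this assay, placing it para to a large group gives a 3.8-fold higher number from compound 1 to compound 4 (0.57 log units; beyond the scatter), a modest weakening that the earlier fluoro compound did not show. Changing 2-fluorophenyl to 4-fluorophenyl gives a 3.6-fold higher number from compound 2 to compound 4 (0.55 log units; beyond the scatter), so where the fluoro sits on the ring matters in this small set. The distance from the cyano compound is large, at a 60-fold higher number from compound 3 to compound 4 (1.78 log units; beyond the scatter), although that step changes both the group and its place, and no measurement available here explains any of these steps.

Going by these compounds, it remains open how a methoxy group or an amine would fare para to a large group. On these data alone, it is also open whether a cyano there would keep a number as low as that of compound 3 or weaken as the fluoro did.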